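A few compounds are considered here, and "the series" means these few. Any claim that something is new, unique, unknown or untested is made for them only; others in the source may bear on it.

Compound 1 `Nc1cccc(CNc2cc(C(F)(F)F)cc3[nH]ncc23)c1` gives 89% in an assay for inhibition of Tryptophan 2,3-dioxygenase (Homo sapiens), with stated times of 10 min and 60 min, tested at 100 uM; on this read-out higher numbers stand for a stronger effect at the one concentration tested and lower numbers for a weaker effect. Among the three numbers measured it stands second highest: the nearest is compound 2 `Oc1ccc(CNc2cc(C(F)(F)F)cc3[nH]ncc23)cc1` with 91%, the furthest compound 3 `FC(F)(F)c1cc(NC[C@H]2CCCN2)c2cn[nH]c2c1` with 84%. All three steps, a number 2 percentage points higher from compound 1 to compound 2 (within the scatter), a number 5 percentage points lower from compound 1 to compound 3 (within the scatter) and a number 7 percentage points lower from compound 2 to compound 3 (within the scatter), lie within the scatter. Compound 4 `CNC(=O)c1cccc(CNc2cc(C(F)(F)F)cc3[nH]ncc23)c1` differs from compound 1 by methylcarbamoyl in place of amino on an aromatic carbon. Among the measured compounds shown here, no measured step touches this position; the three measured steps all exchange the group on the saturated chain carbon bound to the nitrogen on the aromatic ring and all stay within the scatter, so nothing seen so far separates this series in this assay. The expected step is therefore none beyond the scatter, a number 4 percentage points lower from compound 1 to compound 4 (within the scatter). Compound 4 is expected at 85%, in the range 65% to 97%.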

Compound 4, a percentage reported as inhibition, at one concentration (the size of the read-out at that concentration, not a potency): 91%
Estimate against measurement, compound 4: 6 percentage points below; measured number inside the range.
By their numbers in this assay, from the lowest: compounds 3, 1, 2 and 4 (each within the scatter of the next).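

On this aromatic carbon, methylcarbamoyl in place of amino gives a number 2 percentage points higher from compound 1 to compound 4 (within the scatter) in this assay. Among the compounds shown here, this position, untouched by the earlier steps, thus takes 4 heavy atoms in place of 1 with no step beyond the scatter. Like the three exchanges on the saturated chain carbon, this one does not separate the series.

As far as these compounds go, whether a carboxylic acid or a nitrile on this aromatic carbon would give a step beyond the scatter remains open, and a read-out at one concentration gives no potency order for these compounds. Nothing measured here bears on the reason for this result.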